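The compounds below may be only part of what the source reports. "The series", "measured", "known", "first", "only" and "open" are said of these compounds alone.

Compound 2 `C(=C/c1ccccc1)\C=N\c1sc2c(c1-c1nc3ccccc3s1)CCC2` was tested in an ADME assay on HepG2 cells (Homo sapiens) for cytotoxicity, read by MTT assay, with a stated time of 72 h (on this read-out higher numbers stand for lower toxicity in this test and lower numbers for higher toxicity in this test), and gave 215 ug/mL. Among the compounds with values here, of the two numbers measured so far, that of compound 2 is the lower, but only by a margin that carries no weight: its single neighbour, compound 1 `Fc1ccc(/C=N/c2sc3c(c2-c2nc4ccccc4s2)CCC3)cc1`, gives 302 ug/mL in this assay, and the step of a 1.4-fold lower number from compound 1 to compound 2 (0.15 log units; within the scatter) stays within the scatter of repeated measurements. Within the data shown here, compound 3 `Clc1ccc2sc(-c3c(/N=C/C=C/c4ccccc4)sc4c3CCC4)nc2c1` differs from compound 2 by chloro in place of hydrogen on an aromatic carbon, at a place different from the one altered between compound 1 and compound 2. Among the measured compounds shown here, no measured step touches this place, so nothing shows how such a swap shifts the number. For the measured compounds named here, the one step that is known, which exchanged a much larger piece, did not move the number beyond the scatter. For compound 3 the expected step of a 1.1-fold lower number from compound 2 to compound 3 (0.05 log units; within the scatter) is likewise nothing beyond the scatter. Compound 3 is therefore estimated at 190 ug/mL, with a likely range from 95 ug/mL to 380 ug/mL.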

Compound 3, half-maximal cytotoxic concentration: 14.9 ug/mL
Compound 3: middle estimate off by 13-fold (1.11 log units), on the high side; the measured number lies below the stated range.
By their numbers in this assay, from the lowest: compound 3; then compounds 2 and 1 (each within the scatter of the next).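

Chloro in place of hydrogen on this aromatic carbon gives a 14-fold lower number from compound 2 to compound 3 (1.16 log units; beyond the scatter) in this assay, and here a lower number stands for higher toxicity in this test. This position, untouched by the earlier pair, therefore matters far more in this test than the exchange of a much larger piece elsewhere, whose step, a 1.4-fold lower number from compound 1 to compound 2 (0.15 log units; within the scatter), stayed within the scatter. Nothing at hand explains why one added chlorine atom has so large an effect.

With only hydrogen and chloro shown at this carbon, it remains open whether fluoro, a methoxy group or an amine there would lower the number as well. From the compounds shown here alone, it is also open whether chloro would bring a similar step on compound 1, which carries hydrogen at this place.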